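The compounds below may be only part of what the source reports. "The series", "measured", "known", "first", "only" and "open" are said of these compounds alone.

Series notes. In a functional assay for inhibition, tested at 100 ug/mL (a lower number here means a weaker effect, a higher number a stronger effect of the compound at the concentration tested), compound 1 `COc1cc(-c2cc(-c3cc(C(C)C)c(O)cc3C)[nH]c(=O)c2C#N)cc(OC)c1OC` gives 84.5%, compound 3 `COc1cc(OC)c(-c2cc(-c3cc(C(C)C)c(O)cc3C)[nH]c(=O)c2C#N)c(OC)c1` gives 82.5%, and compound 2 `COc1ccc(-c2cc(-c3cc(C(C)C)c(O)cc3C)[nH]c(=O)c2C#N)c(OC)c1` gives 58%, the lowest of the three numbers. For the measured compounds named here, the only measured step between single-change neighbours, a number 24.5 percentage points higher from compound 2 to compound 3 (beyond the scatter), shows that changing the substituents on the aryl ring attached to the shared core can move this assay by a modest amount. Compound 4 `Cc1cc(O)c(C(C)C)cc1-c1cc(-c2ccccc2[N+](=O)[O-])c(C#N)c(=O)[nH]1` carries a different aryl ring altogether: 2-nitrophenyl in place of 2,4-dimethoxyphenyl on an aromatic carbon. Going by the values given here, no measured step exchanges a whole aryl group, so the earlier step only hints at how far such a ring change may reach, not at its direction. The step expected here is a number 2 percentage points higher from compound 2 to compound 4 (within the scatter), that is, none beyond the scatter. Compound 4 is therefore estimated at 60%, expected to fall between 35% and 85%.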

Compound 4, a percentage reported as inhibition, at one concentration (the size of the read-out at that concentration, not a potency): 37.5%
The estimate for compound 4 lay 22.5 percentage points above the measured number; measured number inside the range.
By their numbers in this assay, from the lowest: compound 4; then compound 2; then compounds 3 and 1 (each within the scatter of the next).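

For the compounds shown here, at the place opposite the ring nitrogen, 2-nitrophenyl in place of 2,4-dimethoxyphenyl gives a number 20.5 percentage points lower from compound 2 to compound 4 (beyond the scatter) in this assay, so exchanging the whole aryl group can lower the read-out, whereas the only earlier step raised it. The two groups have equal counts of hydrogen-bond donors and acceptors, so these counts do not separate them. Nothing available explains this drop.

As far as these compounds go, it remains open whether the nitro group or the loss of both methoxy groups accounts for the step. A 2-aminophenyl or 2-carboxyphenyl group at this place would help separate these readings.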